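The source may report more compounds than this note shows. Statements on the series, on what has been measured and on what is new or still open speak of the compounds shown alone.

Compound 1 `N#Cc1ccc(Nc2nc(Oc3ccnc4ccccc34)nc(N3CCN(C(c4ccccc4)c4ccc(Cl)cc4)CC3)n2)cc1C(F)(F)F` gives > 100000 nM in a functional assay on DU-145 cells (Homo sapiens) for cytotoxicity, read by sulforhodamine B assay, with a stated time of 48 h (a lower number here means that less compound is tolerated, a higher number that more compound is tolerated), which is a limit of the assay rather than a number.
Compound 2 `CC1CC(C)CN(c2nc(Nc3ccc(C#N)c(C(F)(F)F)c3)nc(Oc3ccnc4ccccc34)n2)C1` gives > 100000 nM in this assay, again a limit rather than a number.

Compound 2 therefore stands where both measured values sit: the limit of > 100000 nM in this assay, at which 2 of the 2 values shown sit. Going by the values given here, neither compound reaches a measurable value in this assay, so there is no measured step between compounds that differ in one place, and nothing tells how strongly any change on the shared core moves the read-out.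

Compound 3 `CCN1CCN(c2nc(Nc3ccc(C#N)c(C(F)(F)F)c3)nc(Oc3ccnc4ccccc34)n2)CC1` differs from compound 2 in one place: 4-ethylpiperazin-1-yl in place of 3,5-dimethylpiperidin-1-yl on an aromatic carbon. That is, 4-ethylpiperazin-1-yl takes the place of 3,5-dimethylpiperidin-1-yl on an aromatic carbon. With both measured compounds at the limit, the only grounding is that two different groups at this position both left the cells unharmed at the highest concentration tested.

Compound 3 is accordingly expected to give about 100000 nM in this assay, with a plausible range from 30000 nM to 300000 nM. The expected step of a number no higher from compound 2 to compound 3 (the limit leaves the size open) is none beyond the scatter, and most likely the assay will again report only a limit.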

Compound 3, concentration lethal to 50% of the cells: > 100000 nM
Compound 3: no number, only a limit (the forecaster's own chance of this, stated with the estimate: 75%); the middle value sits exactly at the limit.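

Compound 2 and compound 3 both end at a limit of this assay rather than at a number, so no step can be read between them. What the compounds shown leave open is the concentration at which any of them affects these cells, and how strongly a change of group at this position moves the read-out.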